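Cytotoxicity notes: distal aryl swap from compound 3 to compound 4

The source may report more compounds than this note shows. Statements on the series, on what has been measured and on what is new or still open speak of the compounds shown alone.

The series is followed in a toxicity assay on MT4 cells (Homo sapiens) for cytotoxicity, read by MTT assay, with a stated time of 5 days; on this read-out higher numbers stand for lower toxicity in this test and lower numbers for higher toxicity in this test. Compound 1 `Cc1cnc(Nc2ccc(C#N)cc2)nc1Nc1c(F)cc(-c2cncnc2)cc1F` gives 900 nM in this assay, and compound 2 `Cc1cnc(Nc2ccc(C#N)cc2)nc1Nc1c(F)cc(-c2ccnc(F)c2)cc1F` gives 167000 nM. Among the compounds with values here, the only single-point step measured so far is a 190-fold higher number from compound 1 to compound 2 (2.27 log units; beyond the scatter), a large move toward lower toxicity. Compound 3 `Cc1cc(-c2ccc3cc[nH]c3c2)cc(C)c1Nc1ccnc(Nc2ccc(C#N)cc2)n1` gives 5800 nM in this assay, the second highest of the three numbers; it lies nearer to compound 1 than to compound 2, and its gaps to both are beyond the scatter.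

Compound 4 `COc1ncc(-c2cc(C)c(Nc3ccnc(Nc4ccc(C#N)cc4)n3)c(C)c2)cn1` is the next compound for this assay. It differs from compound 3 in one place: 2-methoxypyrimidin-5-yl in place of 1H-indol-6-yl on an aromatic carbon. Within the data shown here, no measured step repeats this change. Among the measured compounds shown here, the one step on record, a 190-fold higher number from compound 1 to compound 2 (2.27 log units; beyond the scatter), concerns an exchange of one six-membered aromatic ring for another on a different core, so it bears on compound 4 only in showing that a change of the distal aryl group can move this assay by a large amount. A step toward a higher number is expected, of uncertain size. Compound 4 is estimated at 15000 nM, with a range from 3000 nM to 80000 nM. The expected step is a 2.6-fold higher number from compound 3 to compound 4 (0.41 log units; beyond the scatter), beyond the scatter, but the wide range reflects the absence of a matching precedent.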

Compound 4, half-maximal cytotoxic concentration: 4800 nM
For compound 4 the middle estimate is 3.1-fold (0.49 log units) above the measured one; measured number inside the range.
By their numbers in this assay, from the lowest: compound 1; then compounds 4 and 3 (each within the scatter of the next); then compound 2.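

In this assay, the group that enters differs from the one that leaves in its rings and in its hydrogen-bond donors and acceptors, yet a 1.2-fold lower number from compound 3 to compound 4 (0.08 log units; within the scatter) is the reading for this exchange on the carbon para to a large group. An exchange of the distal aryl group therefore need not move this read-out, whereas a 190-fold higher number from compound 1 to compound 2 (2.27 log units; beyond the scatter) is the large step on the core of compound 1, so the size of such a step depends on the particular pair of groups or on the core, and these two steps cannot separate the two. No measurement on hand accounts for either step. On these data alone, whether an amine or a carboxylic acid on the distal ring would stay within the scatter of compound 3 remains open. Also open, as far as these compounds go, is whether pyrimidin-5-yl and 2-fluoropyridin-4-yl would differ as widely on the core of compound 3.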